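Switching the benzyl substituent in a weakly active series

A few compounds are considered here, and "the series" means these few. Any claim that something is new, unique, unknown or untested is made for them only; others in the source may bear on it.

Measured so far:
compound 1, `CC(Oc1cccnc1Nc1cnn(C)c1)c1cccc(C(=O)NCc2ccc(F)cc2)c1`: 68500 nM
compound 2, `COc1cccc(CNC(=O)c2cccc(C(C)Oc3cccnc3Nc3cnn(C)c3)c2)c1`: 78600 nM

Both numbers come from a functional assay on HCC78 cells (Homo sapiens) for antiproliferative activity, read by MTT assay, with a stated time of 48 h (on this read-out higher numbers stand for weaker inhibition and lower numbers for stronger inhibition), in which compound 1 gives 68500 nM and compound 2 gives 78600 nM. Among the compounds with values here, the only step between them, a 1.1-fold higher number from compound 1 to compound 2 (0.06 log units; within the scatter), puts 3-methoxyphenyl in place of 4-fluorophenyl on a saturated chain carbon bound to an amide-type nitrogen. Compound 2 therefore stands at the same level as compound 1 within the scatter; nothing separates the two.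

Compound 3, `CC(Oc1cccnc1Nc1cnn(C)c1)c1cccc(C(=O)NCc2ccc(OC(F)(F)F)cc2)c1`, differs from compound 2 in one place: 4-(trifluoromethoxy)phenyl in place of 3-methoxyphenyl on a saturated chain carbon bound to an amide-type nitrogen. Within the data shown here, the one step that bears on this change, from compound 1 to compound 2, exchanged one group on the same saturated chain carbon for another and stayed within the scatter. Among the measured compounds shown here, with only that step to go on, a further exchange on the same chain carbon is expected to leave the number where it is, beyond the scatter in neither direction; the expected step is a 1.0-fold lower number from compound 2 to compound 3 (0.02 log units; within the scatter). Compound 3 is accordingly estimated at 75000 nM in this assay, with a range from 30000 nM to 200000 nM, which leaves room for a limit rather than a number.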

Compound 3, half-maximal inhibitory concentration: 73900 nM
Compound 3: the middle estimate sits 1.0-fold (0.01 log units) above what was measured; low and high end bracket the measured number.
By their numbers in this assay, from the lowest: compounds 1, 3 and 2 (each within the scatter of the next).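

In this assay, a group of 11 heavy atoms replacing one of 8 on a saturated chain carbon bound to an amide-type nitrogen gives a 1.1-fold lower number from compound 2 to compound 3 (0.03 log units; within the scatter) and so leaves the number where it was. Trifluoromethoxy in place of fluoro on an aromatic carbon, a change confined to a single ring substituent, gives a 1.1-fold higher number from compound 1 to compound 3 (0.03 log units; within the scatter) and is equally without effect, so 4-fluorophenyl, 3-methoxyphenyl and 4-(trifluoromethoxy)phenyl cannot be told apart at this place, even with the three fluorines of the largest group. No measurement at hand offers an explanation for this flat result.

Going by these compounds, all three compounds keep an aromatic ring of carbon only at this place, so it remains open whether a group of another kind there, such as a piperidine carrying an amine or a phenyl ring carrying a carboxylic acid, would shift the number. On these data alone, it is also open whether any change to the shared core, rather than to this outer group, would move the series away from its present level in this assay at all.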